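The compounds below may be only part of what the source reports. "The series", "measured", "known", "first", "only" and "open" are said of these compounds alone.

Of the compounds shown here, three from this series have been measured in a functional assay for inhibition, with Rattus norvegicus as the target; on this read-out higher numbers stand for weaker inhibition and lower numbers for stronger inhibition. Compound 1 `CC(C)(C)/N=c1\c(O)c(O)\c1=N/Cc1ccc(C#N)c(Cl)c1` gives 1100 nM in this assay, and compound 2 `CCc1cc(C#N)ccc1C/N=c1\c(O)c(O)\c1=N/C(C)(C)C` gives 240 nM. Compound 3 `CC(C)(C)/N=c1\c(O)c(O)\c1=N/Cc1ccccn1` gives 11500 nM in this assay, the highest of the three numbers, which on this read-out means the weakest inhibition; its gap to compound 1 and its wider gap to compound 2 both lie beyond the usual scatter.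

Compound 4 `CC(C)(C)/N=c1\c(O)c(O)\c1=N/Cc1ccccc1` has not yet been measured. It differs from compound 3 in one place: phenyl in place of pyridin-2-yl on a saturated chain carbon bound to a double-bonded nitrogen. Within the data shown here, the two measured benzyl-bearing compounds, compound 1 and compound 2, carry substituted phenyl rings rather than a bare phenyl, so no single measured step isolates this exact change.

Since compound 1 at 1100 nM and compound 2 at 240 nM both sit well below compound 3, the expectation for compound 4 is a move toward lower numbers, though a modest one. Among the measured compounds shown here, the unsubstituted phenyl of compound 4 lacks the additional groups carried by compound 1 and compound 2, and no measured compound matches it exactly. The expected step is a 3.3-fold lower number from compound 3 to compound 4 (0.52 log units; beyond the scatter) in this assay. For compound 4 the estimated value is 3500 nM, with a range from 1200 nM to 10000 nM.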

Compound 4, half-maximal inhibitory concentration: 3400 nM
The estimate for compound 4 lay 1.0-fold (0.01 log units) above the measured number; measured number inside the range.
By their numbers in this assay, from the lowest: compound 2; then compound 1; then compound 4; then compound 3.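

In this assay, among these compounds, phenyl in place of pyridin-2-yl on a saturated chain carbon bound to a double-bonded nitrogen gives a 3.4-fold lower number from compound 3 to compound 4 (0.53 log units; beyond the scatter), the first step that changes only one place. The two rings have the same number of heavy atoms, but a ring nitrogen and its hydrogen-bond acceptor leave with pyridin-2-yl, so this exchange alone is enough to move the number beyond the usual scatter, towards stronger inhibition. Nothing measured here explains the shift.

From the compounds shown here alone, compound 1 and compound 2 each differ from compound 4 in more than one place, so the separate contributions of their nitrile, chloro and ethyl groups remain open. Also open, going by these compounds, is how a phenyl ring carrying only a nitrile, or a pyridin-3-yl ring, would compare at this place.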